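The compounds below may be only part of what the source reports. "The series", "measured", "known", "first", "only" and "open" are said of these compounds alone.

Three compounds share one core and differ only in the acyl group on the amide. Compound 1 `CCCN(CC[C@H]1CC[C@H](NC(=O)/C=C/c2cccc(Cl)c2)CC1)[C@H]1CCc2nc(N)sc2C1` gives 1.2 nM in an assay on brain for displacement of a labelled ligand from D(3) dopamine receptor (Rattus norvegicus) (on this read-out lower numbers stand for stronger inhibition and higher numbers for weaker inhibition), compound 2 `CCCN(CC[C@H]1CC[C@H](NC(=O)/C=C/c2cccc(OC)c2)CC1)[C@H]1CCc2nc(N)sc2C1` gives 9.3 nM in this assay, and compound 3 `CCCN(CC[C@H]1CC[C@H](NC(=O)c2ccccc2-n2cccn2)CC1)[C@H]1CCc2nc(N)sc2C1` gives 2 nM in this assay. Compound 2 thus stands at the highest number of the three: the change from compound 1 brought a 7.8-fold higher number from compound 1 to compound 2 (0.89 log units; beyond the scatter), and moving on to compound 3 brought a 4.7-fold lower number from compound 2 to compound 3 (0.67 log units; beyond the scatter), while between compound 1 and compound 3 the step was a 1.7-fold higher number from compound 1 to compound 3 (0.22 log units; within the scatter).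

Compound 4 `CCCN(CC[C@H]1CC[C@H](NC(=O)c2ccc(-n3cccn3)cc2)CC1)[C@H]1CCc2nc(N)sc2C1` is reached from compound 2 by one change (4-(1H-pyrazol-1-yl)phenyl in place of 2-(3-methoxyphenyl)ethenyl on a carbonyl carbon). Within the data shown here, the step that bears on it most directly is the one from compound 2 to compound 3, where a 2-(1H-pyrazol-1-yl)phenyl group likewise replaced the 2-(3-methoxyphenyl)ethenyl group and the number fell by a 4.7-fold lower number from compound 2 to compound 3 (0.67 log units; beyond the scatter). Among the measured compounds shown here, no measured pair separates a 4-(1H-pyrazol-1-yl)phenyl from a 2-(1H-pyrazol-1-yl)phenyl group, so the size of that remaining difference is unknown. Compound 4 is therefore expected to give a lower number than compound 2, with the step estimated at a 3.1-fold lower number from compound 2 to compound 4 (0.49 log units; beyond the scatter). The estimate for compound 4 in this assay is 3 nM, expected to lie between 0.8 nM and 12 nM.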

Compound 4, inhibition constant: 3 nM
Compound 4: middle estimate and measured number agree at the digits printed, within the range that was stated.
By their numbers in this assay, from the lowest: compounds 1, 3 and 4 (each within the scatter of the next, the first and the last beyond it); then compound 2.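

In this assay, the 4-(1H-pyrazol-1-yl)phenyl group on the carbonyl carbon improves on the 2-(3-methoxyphenyl)ethenyl group, with a 3.1-fold lower number from compound 2 to compound 4 (0.49 log units; beyond the scatter), so a step of this kind is no longer tied to the 2-(1H-pyrazol-1-yl)phenyl group of compound 3. The two pyrazolylphenyl groups cannot be told apart at this position, as a 1.5-fold higher number from compound 3 to compound 4 (0.18 log units; within the scatter), yet only compound 4 separates from the chlorinated compound, with a 2.5-fold higher number from compound 1 to compound 4 (0.40 log units; beyond the scatter), whereas compound 3 stayed within the scatter of compound 1. Nothing available here accounts for these differences.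

The compounds shown leave open how a plain phenyl, a 3-(1H-pyrazol-1-yl)phenyl or a 4-(1H-imidazol-1-yl)phenyl group would read at this carbonyl carbon, and so whether the pyrazole ring contributes anything beyond the phenyl ring that carries it. Among these compounds, they also leave open whether a chloro substituent on the 4-(1H-pyrazol-1-yl)phenyl group would bring a step like the one that separates compound 1 from compound 2.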